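The source may hold more compounds than are shown below. What is called first, only, known or untested is meant among the compounds shown, and "the series" means these compounds.

Two measured compounds share one core and differ only in the ring bound to the double-bonded chain carbon. Compound 1 `O=C1C(=Cc2ccc(Br)cc2)C(=O)N(c2ccc(Cl)cc2)N1c1ccc(Cl)cc1` and compound 2 `COc1cccc(C=C2C(=O)N(c3ccc(Cl)cc3)N(c3ccc(Cl)cc3)C2=O)c1` were both tested in a functional assay on SMMC-7721 cells (Homo sapiens) for cytotoxicity, read by MTT assay, with a stated time of 72 h; on this read-out higher numbers stand for weaker inhibition and lower numbers for stronger inhibition; compound 1 gives 16600 nM, and compound 2 gives 30200 nM. The step of a 1.8-fold higher number from compound 1 to compound 2 (0.26 log units; within the scatter) stays within the usual scatter, so swapping the ring there left the number essentially unchanged. Going by the values given here, of the two numbers, the one for compound 1 is the smaller, but the gap to compound 2 falls within the scatter.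

Compound 3 `O=C1C(=Cc2ccc(F)cc2F)C(=O)N(c2ccc(Cl)cc2)N1c1ccc(Cl)cc1` is not yet measured. Its change from compound 1 is 2,4-difluorophenyl in place of 4-bromophenyl on a double-bonded chain carbon bound to a double-bonded ring carbon. Among the compounds with values here, the only measured step, from compound 1 to compound 2, also replaced the ring at this place and was within the scatter; it is the sole guide, and it involved a different group, so it bears only loosely. No step beyond the scatter is therefore expected in this assay, the estimated step being a 1.2-fold higher number from compound 1 to compound 3 (0.08 log units; within the scatter). Compound 3 is expected to give about 20000 nM, with a likely range from 8000 nM to 50000 nM.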

Compound 3, half-maximal inhibitory concentration: 35800 nM
The estimate for compound 3 lay 1.8-fold (0.25 log units) below the measured number; measured number inside the range.
By their numbers in this assay, from the lowest: compounds 1, 2 and 3 (each within the scatter of the next, the first and the last beyond it).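

Going by these compounds alone, measured in this assay, the step of a 2.2-fold higher number from compound 1 to compound 3 (0.33 log units; beyond the scatter) is the first at this place to lie beyond the scatter, so changing the ring on the double-bonded chain carbon can shift the number, though only modestly. The step of a 1.2-fold higher number from compound 2 to compound 3 (0.07 log units; within the scatter) stays within the scatter, so 2,4-difluorophenyl and 3-methoxyphenyl cannot be told apart here, and compound 1 separates from compound 3 but not from compound 2. No evidence at hand accounts for the step between 4-bromophenyl and 2,4-difluorophenyl.

All three rings shown are phenyl rings carrying halogen or methoxy groups, so it remains open what an amine or a carboxylic acid on this ring would do. On these data alone, the rest of the shared core stays the same throughout, so the effect of any change there is also open.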